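A few compounds are considered here, and "the series" means these few. Any claim that something is new, unique, unknown or untested is made for them only; others in the source may bear on it.

In an ADME assay on HL-60 cells (Homo sapiens) for cytotoxicity, read by MTT assay, with a stated time of 24 h (on this read-out lower numbers stand for stronger inhibition and higher numbers for weaker inhibition), compound 1 (`CC(C)CN(C)Cc1ccc(C2=CCCN(C)C2)cc1`) gives > 50000 nM as a limit and not a number. Compound 2 (`CN1CCC=C(c2ccc(CN(C)Cc3ccc(Cl)cc3)cc2)C1`) gives > 50000 nM as a limit and not a number, so it has no measured position of its own. For the measured compounds named here, the series so far stands at the limit of > 50000 nM in this assay, at which 2 of the 2 values shown sit, and holds no number.

Compound 3 (`CN1CCC=C(c2ccc(CN(C)C/C=C/c3ccccc3)cc2)C1`) differs from compound 2 as follows: 2-phenylethenyl in place of 4-chlorophenyl on a saturated chain carbon bound to an amine nitrogen (the swap falls on a saturated chain carbon bound to an amine nitrogen). Going by the values given here, the only measured step at that place (a step that the two limits leave unreadable from compound 1 to compound 2) has no size to carry over. Among the compounds with values here, with compound 2 as the reference and that step as the only guide, no change beyond the scatter is expected (a number no higher from compound 2 to compound 3 (the limit leaves the size open)) in this assay for now. For compound 3 the estimate is 50000 nM (expected range 25000 nM to 100000 nM) and a report as a limit is the likeliest outcome.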

Compound 3, half-maximal inhibitory concentration: > 50000 nM
Compound 3: a limit, no number; the forecaster's own chance of this, stated with the estimate: 75%; the middle value sits exactly at the limit.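

No step can be read among compound 1, compound 2 and compound 3, as each value is a limit and not a number: the limit of > 50000 nM in this assay, at which 3 of the 3 values shown sit.

The compounds shown leave open whether any group on the saturated chain carbon bound to an amine nitrogen gives a measurable value in this assay.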